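A Pyridazine Variant of Compound 1 and Its Expected Half-Life

A few compounds are considered here, and "the series" means these few. Any claim that something is new, unique, unknown or untested is made for them only; others in the source may bear on it.

In an ADME assay on the whole organism (strain Han-Wistar) for metabolic stability, with Rattus norvegicus as the target, read by LC-MS, at a dose of 1 mg/kg by the intravenous route (a lower number here means that the compound disappears faster, a higher number that the compound lasts longer), compound 1 `Cc1ccc([C@@H](C)Oc2cc3onc(CCC(=O)O)c3cc2Cl)nc1` gives 3.6 h, the second highest of three numbers. Compound 2 `C[C@@H](Oc1cc2onc(CCC(=O)O)c2cc1Cl)c1ccc(Cl)cn1` gives 8.7 h, and the step of a 2.4-fold higher number from compound 1 to compound 2 (0.38 log units; beyond the scatter) is modest. Compound 3 `CCOc1cc2oc(=O)n(CCC(=O)O)c2cc1Cl`, built on a different core, gives 0.43 h in this assay. Compound 4 `Cc1ccc([C@@H](C)Oc2cc3onc(CCC(=O)O)c3cc2Cl)nn1` differs from compound 1 only as follows: 6-methylpyridazin-3-yl in place of 5-methylpyridin-2-yl on a saturated chain carbon bound to an oxygen on an aromatic ring and a saturated chain carbon. Among the measured compounds shown here, no measured step involves this ring exchange, and the one measured step touches a different position, so it offers no direct guide. With no evidence for a shift either way, compound 4 is expected to stay within the scatter of compound 1, an estimated step of a 1.0-fold lower number from compound 1 to compound 4 (0.01 log units; within the scatter). Compound 4 is therefore estimated at 3.5 h, with a range from 1.7 h to 7.5 h.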

Compound 4, half-life in the Rattus norvegicus assay: 1.5 h
Beside the measured number, compound 4's estimate is 2.3-fold (0.37 log units) above it, outside the stated range (below it).
By their numbers in the Rattus norvegicus assay, from the lowest: compound 3; then compound 4; then compound 1; then compound 2.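

In the Rattus norvegicus assay the ring on this saturated chain carbon itself proves to count, not only its substituent: 6-methylpyridazin-3-yl gives a 2.4-fold lower number from compound 1 to compound 4 (0.38 log units; beyond the scatter), and in place of 5-chloropyridin-2-yl it gives a 5.8-fold lower number from compound 2 to compound 4 (0.76 log units; beyond the scatter). In a physicochemical assay for solubility, with a stated time of 24 h (on this read-out lower numbers stand for lower solubility and higher numbers for higher solubility), compound 1 gives > 860 ug/mL, a limit of the assay and not a number: the limit of > 860 ug/mL in the physicochemical assay, at which 1 of the 2 values shown sits. In the physicochemical assay compound 4 gives 230 ug/mL, which is an at least 3.7-fold lower number from compound 1 to compound 4 (0.57 log units; beyond the scatter).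

Still open, going by these compounds, is whether a trifluoromethyl group in place of the methyl on 6-methylpyridazin-3-yl would shift either number. The data do not tell what lies behind either drop.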